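A few compounds are considered here, and "the series" means these few. Any claim that something is new, unique, unknown or untested is made for them only; others in the source may bear on it.

Measured so far in an ADME assay on PBMC cells (Homo sapiens) for cytotoxicity; on this read-out lower numbers stand for higher toxicity in this test and higher numbers for lower toxicity in this test:

compound 1, `CC(CCNC(=O)c1c(Cl)cncc1Cl)N1CCC(C(Oc2ccncc2)c2ccc(Br)cc2)CC1`, gives 31200 nM
compound 2, `COc1cccc(OC(c2ccc(C(F)(F)F)cc2)C2CCN(C(C)CCNC(=O)c3c(Cl)cncc3Cl)CC2)n1`, gives 32700 nM
compound 3, `CC(CCNC(=O)c1c(Cl)cncc1Cl)N1CCC(C2(c3ccc(C(F)(F)F)cc3)Cc3ccccc3O2)CC1`, gives 33800 nM

Compound 2 stands second highest of the three numbers. For the measured compounds named here, its nearest neighbour is compound 3, its furthest compound 1, and both gaps lie within the scatter of repeated measurements, so the three values cannot be told apart; no compound is set above or below another on this read-out. Going by the values given here, the three measured compounds differ from one another at several places at once, and no single-change pair among them is available, so no measured step can be quoted.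

Compound 4, `CC(CCNC(=O)c1c(Cl)cncc1Cl)N1CCC(C(Oc2ccccc2C(F)(F)F)c2ccc(C(F)(F)F)cc2)CC1`, is the next candidate for this assay. It is reached from compound 2 by one change:

2-(trifluoromethyl)phenyl in place of 6-methoxypyridin-2-yl on an oxygen on a saturated carbon

For this assay the expected step from compound 2 to compound 4 is none beyond the scatter: the three measured compounds carry quite different groups in this region of the molecule and still agree, so a change at the same place is not expected to move the number noticeably. Compound 4 is thus estimated at 32000 nM, with a range of 16000 nM to 64000 nM, and the expected step is a 1.0-fold lower number from compound 2 to compound 4 (0.01 log units; within the scatter).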

Compound 4, half-maximal cytotoxic concentration: 12500 nM
Compound 4: the middle estimate sits 2.6-fold (0.41 log units) above what was measured, outside the stated range (below it).
By their numbers in this assay, from the lowest: compound 4; then compounds 1, 2 and 3 (each within the scatter of the next).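

In this assay, 2-(trifluoromethyl)phenyl in place of 6-methoxypyridin-2-yl on an oxygen on a saturated carbon gives a 2.6-fold lower number from compound 2 to compound 4 (0.42 log units; beyond the scatter), so this position can shift the read-out towards higher toxicity in this test, although the step is modest. The agreement of compound 1, compound 2 and compound 3 within the scatter therefore cannot be taken to mean that the group on this oxygen is free to vary, since those compounds differ at several places and none of them isolates this change. No measurement at hand bears on what lies behind the step.

The single change swaps the ring type and the substituent together, so the shown compounds do not tell whether the step follows the loss of the ring nitrogen, the loss of the methoxy group or the arrival of the trifluoromethyl group. A plain phenyl or a 2-methoxyphenyl on the same oxygen would separate these parts, and a 2-cyanophenyl would test whether the step is specific to trifluoromethyl.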